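Cyanoaziridine ureas: from a butyl urea to the bare urea

The source may report more compounds than this note shows. Statements on the series, on what has been measured and on what is new or still open speak of the compounds shown alone.

Three cyanoaziridine ureas have been tested in a functional assay on WiDr cells (Homo sapiens) for inhibition; on this read-out higher numbers stand for weaker inhibition and lower numbers for stronger inhibition. Compound 1 `N#CC1CN1C(=O)NCc1ccccc1` gives 5300 nM, and compound 3 `N#CC1CN1C(=O)Nc1ccccc1` gives 5000 nM. Compound 2 `CCCCNC(=O)N1CC1C#N` gives 14000 nM, the highest of the three numbers, and its gaps to compound 1 and to compound 3 both lie beyond the usual scatter. Compound 4 `N#CC1CN1C(N)=O` differs from compound 2 in one place: hydrogen in place of butyl on an amide-type nitrogen. With nothing left on that nitrogen but hydrogen, the step is expected to raise the number again, and the estimated change from compound 2 to compound 4 in this assay is a 2.1-fold higher number from compound 2 to compound 4 (0.33 log units; beyond the scatter). Compound 4 is therefore expected to give about 30000 nM, in a range from 8000 nM to 100000 nM.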

Compound 4, half-maximal inhibitory concentration: > 280000 nM
Compound 4 ended at the assay's limit; the forecaster's own chance of this, stated with the estimate: 30%; at least 9.3-fold (0.97 log units) between middle value and limit.
By their numbers in this assay, from the lowest: compounds 3 and 1 (each within the scatter of the next); then compound 2. At a limit, above all of these: compound 4.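

In this assay, replacing butyl with hydrogen on the amide-type nitrogen gives an at least 20-fold higher number from compound 2 to compound 4 (1.30 log units; beyond the scatter). This shows that the group on this nitrogen can decide whether the urea gives a measurable number at all: compound 1, compound 2 and compound 3 all carry a carbon group there and give numbers, while compound 4, with only hydrogen, does not. The value of compound 4 is a limit of the assay, so the full size of the step stays unknown: the limit of > 280000 nM in this assay, at which 1 of the 4 values shown sits.

The compounds shown leave open how a methyl group or a longer chain on this nitrogen would fall on this read-out. They also leave open whether a chain ending in an amine or a carboxylic acid would be tolerated there.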